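Swapping a Pyrrole for a Chlorophenyl Thioether

A few compounds are considered here, and "the series" means these few. Any claim that something is new, unique, unknown or untested is made for them only; others in the source may bear on it.

Compound 1, `Cc1cc(-n2cccc2)c2ncc(CSCCc3ccccc3)n2c1`: 26 ug/mL
Compound 2, `Cc1cc(-n2cccc2)c2ncc(CSCc3ccccc3)n2c1`: 15 ug/mL

Both were tested in an ADME assay on HEL cells (Homo sapiens) for cytotoxicity, with a stated time of 3 days; on this read-out lower numbers stand for higher toxicity in this test and higher numbers for lower toxicity in this test. Compound 1 gives the highest of the two numbers; the nearest step is a 1.7-fold lower number from compound 1 to compound 2 (0.24 log units; within the scatter). Compound 3, `Cc1cc(Sc2ccc(Cl)cc2)c2ncc(CSCCc3ccccc3)n2c1`, differs from compound 1 by (4-chlorophenyl)sulfanyl in place of 1H-pyrrol-1-yl on an aromatic carbon. Among the measured compounds shown here, the only measured step concerns a different part of the shared core and lies within the scatter, so nothing measured bears on this change. No step beyond the scatter is therefore expected in this assay. Compound 3 is estimated at 20 ug/mL, within 6 ug/mL to 60 ug/mL, an expected step of a 1.3-fold lower number from compound 1 to compound 3 (0.11 log units; within the scatter).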

Compound 3, half-maximal cytotoxic concentration: 100 ug/mL
Compound 3: the middle estimate sits 5.0-fold (0.70 log units) below what was measured; measured number outside the range, above it.
By their numbers in this assay, from the lowest: compounds 2 and 1 (each within the scatter of the next); then compound 3.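

In this assay, the aromatic carbon that carries the 1H-pyrrol-1-yl group proves to matter: (4-chlorophenyl)sulfanyl in its place gives a 3.8-fold higher number from compound 1 to compound 3 (0.59 log units; beyond the scatter) and so means lower toxicity in this test, by more than the usual scatter. The earlier pair, which differed only in the chain on the sulfur, could not show this. Nothing available explains the shift. Going by these compounds, it remains open which part of the new group counts, the sulfur link or the chlorine, and whether a plain phenylsulfanyl group or an amine on the same carbon would give a similar number.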